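A few compounds are considered here, and "the series" means these few. Any claim that something is new, unique, unknown or untested is made for them only; others in the source may bear on it.

Of the compounds shown here, two have been read so far, and the third differs from the second at one place. In a functional assay on DU-145 cells (Homo sapiens) for inhibition, read by trypan blue exclusion, with a stated time of 96 h (on this read-out higher numbers stand for weaker inhibition of growth and lower numbers for stronger inhibition of growth), compound 1 `Cc1ccc(CS(=O)(=O)/C(=C/c2ccc(Br)cc2)C(=O)c2ccc(Cl)cc2)cc1` gives 25000 nM. Compound 2 `Cc1ccc(S(=O)(=O)/C(=C/c2c(O)cc(O)cc2O)C(=O)c2ccc(Cl)cc2)cc1` gives > 100000 nM. That figure is a limit of the assay and not a number, so compound 2 has no exact position in the series.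

Compound 3 `Cc1ccc(CS(=O)(=O)/C(=C/c2c(O)cc(O)cc2O)C(=O)c2ccc(Cl)cc2)cc1` keeps the rest of compound 2 and takes 4-methylbenzyl in place of 4-methylphenyl on a sulfonyl sulfur. Going by the values given here, no measured pair isolates this change, so any forecast is loose. Among the compounds with values here, the expectation rests on compound 1, the only measured compound with 4-methylbenzyl on the sulfonyl sulfur, which gives 25000 nM in this assay. A modest move towards stronger inhibition of growth is therefore expected, though compound 3 may also return only a limit. The expected step is an at least 2.5-fold lower number from compound 2 to compound 3 (0.39 log units; beyond the scatter). For compound 3 the estimated value is 40000 nM, with an expected range of 10000 nM to 100000 nM.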

Compound 3, concentration for 50% growth inhibition: > 100000 nM
Compound 3: a limit, no number; the forecaster's own chance of this, stated with the estimate: 35%; middle value at least 2.5-fold (0.39 log units) away from the limit.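

In this assay compound 3 gives > 100000 nM, which is a limit of the assay and not a number, so 4-methylbenzyl in place of 4-methylphenyl on a sulfonyl sulfur brings no readable value to this 2,4,6-trihydroxyphenyl series, and the step between the two compounds cannot be read. Holding 4-methylbenzyl constant does give the first readable one-place comparison in the series: 2,4,6-trihydroxyphenyl in place of 4-bromophenyl on a double-bonded chain carbon gives an at least 4.0-fold higher number from compound 1 to compound 3 (0.60 log units; beyond the scatter). The change at the sulfonyl sulfur therefore has no measurable size so far, and the two 2,4,6-trihydroxyphenyl compounds can be placed only at the top of the read-out, not ranked against each other: the limit of > 100000 nM in this assay, at which 2 of the 3 values shown sit.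

As far as these compounds go, how far compound 2 and compound 3 lie past that limit stays open, as does any difference between 4-methylbenzyl and 4-methylphenyl on a sulfonyl sulfur when 4-bromophenyl is kept on the chain carbon. Also open, from the compounds shown here alone, is whether a methoxy group or an amine on the ring, in place of the three hydroxyl groups, would bring the values back into a readable range.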